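From Cyano to Fluoro: An Estimate for Compound 4

This account rests on a few compounds, and the source may have more. Where it says the series, first, only, none or still open, it means among the compounds named here.

Of the compounds shown here, three have been measured in a functional assay on HeLa cells (Homo sapiens) for antiproliferative activity, read by sulforhodamine B assay, with a stated time of 72 h; on this read-out lower numbers stand for stronger inhibition and higher numbers for weaker inhibition. Compound 1 `N#Cc1ccc(NC(=S)N/N=C/c2ccc3ccccc3n2)cc1` gives 20000 nM, the highest number of the three. Compound 2 `CC(C)c1cccc(C(C)C)c1NC(=S)N/N=C/c1ccc2ccccc2n1` gives 16400 nM, which lies within the scatter of compound 1. Compound 3 `NC(=S)N/N=C/c1cc2cccnc2s1` gives 6290 nM, a lower number than compound 1 by a margin beyond the scatter. Compound 4 `Fc1ccc(NC(=S)N/N=C/c2ccc3ccccc3n2)cc1` is not yet measured. It differs from compound 1 in one place: fluoro in place of cyano on an aromatic carbon. Among the compounds with values here, no measured pair shows this change, so the expectation rests only on the range of numbers already seen. The expected step, a 1.3-fold lower number from compound 1 to compound 4 (0.12 log units; within the scatter), is small and not clearly beyond the scatter in either direction. On that basis compound 4 is estimated at 15000 nM, within a range from 5000 nM to 45000 nM.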

Compound 4, half-maximal inhibitory concentration: 33200 nM
For compound 4 the middle estimate is 2.2-fold (0.35 log units) below the measured one, within the range that was stated.
By their numbers in this assay, from the lowest: compound 3; then compounds 2, 1 and 4 (each within the scatter of the next, the first and the last beyond it).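

In this assay, within the data shown here, fluoro in place of cyano gives a 1.7-fold higher number from compound 1 to compound 4 (0.22 log units; within the scatter) and so supplies the first pair of measured compounds that differ in one place. At this aromatic carbon, para to a large group, the read-out does not clearly separate the two groups on this core. No measurement shown here bears on the reason for this result. Going by these compounds, it remains open whether an amine, a carboxylic acid or a methoxy group at this place would give a number beyond the scatter of compound 1.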